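The source may report more compounds than this note shows. Statements on the series, on what has been measured and on what is new or still open speak of the compounds shown alone.

Results so far in a functional assay on SGC-7901 cells (Homo sapiens) for antiproliferative activity, read by MTT assay, with a stated time of 72 h (a lower number here means a stronger inhibitor, a higher number a weaker inhibitor), are these:
- Compound 1 `COc1ccc(-c2cc(C(=O)O)sc2-c2cc(OC)c(OC)c(OC)c2)cc1` gives 4220 nM in this assay
- Compound 2 `COc1ccc(-c2cc(C(=O)O)sc2-c2cc(OC)c(OC)c(OC)c2)cc1OCc1ccccc1` gives > 100000 nM as a limit, not a number
- Compound 3 `COc1ccc(-c2ccsc2-c2cc(OC)c(OC)c(OC)c2)cc1` gives 2740 nM in this assay

Compound 3 gives 2740 nM and compound 1 gives 4220 nM, so these two values sit within the usual scatter of each other. Compound 4 `COc1ccc(-c2ccsc2-c2cc(OC)c(OC)c(OC)c2)cc1OCc1ccccc1` differs from compound 3 by benzyloxy in place of hydrogen on an aromatic carbon with benzyloxy in place of hydrogen on an aromatic carbon, ortho to a methoxy group.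

Among the measured compounds shown here, two measured steps bear on this. The same change gave a large step, an at least 23-fold higher number from compound 1 to compound 2 (1.37 log units; beyond the scatter), and it ended at a limit of the assay. The step of a 1.5-fold lower number from compound 1 to compound 3 (0.19 log units; within the scatter), with hydrogen in place of carboxy, lies within the scatter, so compound 3 offers a similar starting point. A large rise in the number in this assay is therefore expected, meaning a weaker inhibitor, although this rests on a single pair. The estimated change is a 15-fold higher number from compound 3 to compound 4 (1.16 log units; beyond the scatter) in all. For compound 4 the expected value is 40000 nM, with an estimated range of 6000 nM to 100000 nM here.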

Compound 4, half-maximal inhibitory concentration: > 100000 nM
Compound 4: only a limit was reported (the forecaster's own chance of this, stated with the estimate: 40%); middle value at least 2.5-fold (0.39 log units) away from the limit.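

In this assay, benzyloxy in place of hydrogen gives an at least 36-fold higher number from compound 3 to compound 4 (1.56 log units; beyond the scatter), so the large loss of activity is not limited to the core that carries the carboxy group. The limit leaves the size of the loss on each core unsettled: the same change on two cores in this assay, an at least 23-fold higher number (1.37 log units; beyond the scatter) from compound 1 to compound 2 and an at least 36-fold higher number (1.56 log units; beyond the scatter) from compound 3 to compound 4; the limit leaves it open whether they differ Compound 2 and compound 4 both end at a limit rather than a number, so the step between them, hydrogen in place of carboxy, cannot be read, and any effect of the carboxy group with benzyloxy present stays hidden: the limit of > 100000 nM in this assay, at which 2 of the 4 values shown sit.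

Only hydrogen and benzyloxy are shown at this position, ortho to a methoxy group. From the compounds shown here alone, it remains open whether a hydroxy group, an ethoxy group or an amine there would keep activity close to that of compound 3.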